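Extending an amide methyl to ethyl: expected cytotoxicity

The source may hold more compounds than are shown below. What is called first, only, known or untested is meant among the compounds shown, and "the series" means these compounds.

Compound 1 `O=C(O)c1cccn1-c1ccc2c(c1)B(O)OC2`. In an ADME assay on L929 cells (Mus musculus) for cytotoxicity, read by resazurin assay, with a stated time of 72 h (on this read-out lower numbers stand for stronger inhibition and higher numbers for weaker inhibition), compound 1 gives > 10 ug/mL, which is a limit of the assay and not a number.
Compound 2 `O=C(NC1CCCCC1)c1cccn1-c1ccc2c(c1)B(O)OC2`. In this assay compound 2 gives > 10 ug/mL, again a limit.
Compound 3 `CNC(=O)c1cccn1-c1ccc2c(c1)B(O)OC2`. In this assay compound 3 gives > 10 ug/mL, again a limit.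

For the measured compounds named here, compound 3 therefore stands at the limit of > 10 ug/mL in this assay, at which 3 of the 3 values shown sit, where every value so far sits, and it can be placed no more precisely than that. Compound 4 `CCNC(=O)c1cccn1-c1ccc2c(c1)B(O)OC2` differs from compound 3 by methyl in place of hydrogen on a saturated chain carbon bound to an amide-type nitrogen. The measured steps that bear on this change are a step that the two limits leave unreadable from compound 2 to compound 3, a step that the two limits leave unreadable from compound 1 to compound 3 and a step that the two limits leave unreadable from compound 1 to compound 2; none of them has a readable size, since both ends of each sit at the limit. Changes at the amide substituent, from methyl up to cyclohexyl, have thus left the read-out at the limit in every case shown. The step from compound 3 to compound 4 is accordingly expected to be a step that the limit leaves unreadable from compound 3 to compound 4, not beyond the scatter. Compound 4 is expected to give 20 ug/mL in this assay, within 8 ug/mL to 60 ug/mL, most likely reported only as a limit.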

Compound 4, half-maximal inhibitory concentration: > 10 ug/mL
Compound 4: only a limit was reported; the forecaster's own chance of this, stated with the estimate: 85%; the middle value lies beyond the limit too.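

Compound 4 sits at the same limit as compound 1, compound 2 and compound 3 in this assay, and no step to compound 4 can be read: the limit of > 10 ug/mL in this assay, at which 4 of the 4 values shown sit.

The compounds shown leave open what actual value any of them has beyond that limit, and whether the amide substituent alters it.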